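Swapping a butyl chain for a pentylphenyl group

The source may hold more compounds than are shown below. What is called first, only, known or untested is meant among the compounds shown, and "the series" means these compounds.

The shared core is a lactone ring carrying two benzyloxy groups, linked through a hydroxylated two-carbon bridge to a five-membered aromatic ring with three nitrogens. Compound 1 `O=C1O[C@H]([C@@H](O)Cn2cc(-c3cccc(O)c3)nn2)C(OCc2ccccc2)=C1OCc1ccccc1` carries a 3-hydroxyphenyl on that ring; in a functional assay on HeLa cells (Homo sapiens) for antiproliferative activity, read by MTT assay, with a stated time of 72 h (a lower number here means a stronger inhibitor, a higher number a weaker inhibitor), compound 1 gives 39300 nM. Going by the values given here, compound 2 `CCCCc1cn(C[C@H](O)[C@H]2OC(=O)C(OCc3ccccc3)=C2OCc2ccccc2)nn1` carries a butyl there instead, and in this assay compound 2 gives 18100 nM, which is the lowest of the two numbers known so far. Among the compounds with values here, the only step on record, a 2.2-fold lower number from compound 1 to compound 2 (0.34 log units; beyond the scatter), shows that replacing the hydroxyphenyl by a short chain lowered the number modestly.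

Compound 3 `CCCCCc1ccc(-c2cn(C[C@H](O)[C@H]3OC(=O)C(OCc4ccccc4)=C3OCc3ccccc3)nn2)cc1` takes the next step: 4-pentylphenyl in place of butyl on an aromatic carbon. Within the data shown here, no measured pair covers an aryl group that carries a long chain, so the one known step bears only loosely, and it gives no firm direction for adding an aromatic ring back while keeping chain length. A step of roughly the same size, or none beyond the scatter, is the honest expectation. Compound 3 is therefore estimated at 11000 nM, within 3500 nM to 35000 nM, which is expected to amount to a 1.6-fold lower number from compound 2 to compound 3 (0.22 log units; within the scatter).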

Compound 3, half-maximal inhibitory concentration: 8390 nM
For compound 3 the middle estimate is 1.3-fold (0.12 log units) above the measured one; measured number inside the range.
By their numbers in this assay, from the lowest: compound 3; then compound 2; then compound 1.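

In this assay, this position on the five-membered aromatic ring accepts a much larger group with no loss, and the number even falls: 4-pentylphenyl in place of butyl gives a 2.2-fold lower number from compound 2 to compound 3 (0.33 log units; beyond the scatter) and so brings the lowest number of the three. The earlier pair could be read as a chain doing better than an aromatic ring, but compound 3 goes against that reading, since it carries a six-membered aromatic ring and still has a lower number than compound 2. Compound 1 also carries such a ring, yet 4-pentylphenyl in place of 3-hydroxyphenyl gives a 4.7-fold lower number from compound 1 to compound 3 (0.67 log units; beyond the scatter) and the outcome therefore follows what the aryl group carries, with no measurement here offering an explanation for these shifts.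

The compounds shown leave open how much of the change belongs to the phenyl ring and how much to the pentyl chain on it, and an unsubstituted phenyl or a straight pentyl at this position would separate the two. Also open, as far as these compounds go, is how a longer chain on the phenyl ring, or an amine or a carboxylic acid there, would compare.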